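Indolylmethyl in place of bromopyridinylmethyl on a shared core

The source may hold more compounds than are shown below. What is called first, only, known or untested is meant among the compounds shown, and "the series" means these compounds.

Measured compounds and their values:
compound 1 `Clc1cccc(Nc2ncnc3ccc(NCc4cccnc4)cc23)c1` — 2670 nM
compound 2 `Clc1cccc(Nc2ncnc3ccc(NCc4cccc(Br)n4)cc23)c1` — 2950 nM
compound 3 `Clc1cccc(Nc2ncnc3ccc(NCc4ncc5ccccc5n4)cc23)c1` — 1710 nM

The three compounds share one core and differ only in the aromatic group carried on a saturated chain carbon bound to a nitrogen on that core. In a functional assay on A549 cells (Homo sapiens) for antiproliferative activity, read by MTT assay, with a stated time of 48 h (on this read-out lower numbers stand for stronger inhibition and higher numbers for weaker inhibition), compound 2 gives the highest of the three numbers, yet its steps to the others are small: a 1.1-fold higher number from compound 1 to compound 2 (0.04 log units; within the scatter) and a 1.7-fold lower number from compound 2 to compound 3 (0.24 log units; within the scatter). The third pairing is of the same kind, a 1.6-fold lower number from compound 1 to compound 3 (0.19 log units; within the scatter).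

Compound 4 `Clc1cccc(Nc2ncnc3ccc(NCc4c[nH]c5ccccc45)cc23)c1` is not yet measured. It arises from compound 2 by 1H-indol-3-yl in place of 6-bromopyridin-2-yl on a saturated chain carbon bound to a nitrogen on an aromatic ring. Every measured exchange of this group lies within the scatter, so no step beyond the scatter is expected here either: the expected step is a 1.2-fold lower number from compound 2 to compound 4 (0.07 log units; within the scatter). Because compound 2 gives 2950 nM and the neighbouring exchanges stayed flat, compound 4 is estimated at 2500 nM in this assay, with a range from 900 nM to 7000 nM.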

Compound 4, half-maximal inhibitory concentration: 2330 nM
The estimate for compound 4 lay 1.1-fold (0.03 log units) above the measured number, within the range that was stated.
By their numbers in this assay, from the lowest: compounds 3, 4, 1 and 2 (each within the scatter of the next).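

In this assay, 1H-indol-3-yl on a saturated chain carbon bound to a nitrogen on an aromatic ring stays within the scatter of all three earlier groups (a 1.3-fold lower number from compound 2 to compound 4 (0.10 log units; within the scatter); a 1.4-fold higher number from compound 3 to compound 4 (0.13 log units; within the scatter); a 1.1-fold lower number from compound 1 to compound 4 (0.06 log units; within the scatter)). Unlike 6-bromopyridin-2-yl, the entering group has a hydrogen-bond donor, no hydrogen-bond acceptor and a five-membered aromatic ring, so the flat picture at this position now extends to a change of that kind. Nothing measured here bears on why the numbers stay so close.

All four groups shown are aromatic, so it remains open whether a saturated amine such as piperidine or a carboxylic acid at this place would give a step beyond the scatter. On these data alone, a longer chain between the nitrogen and the aromatic ring also remains untested by these compounds.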